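Aryl selenocyanate and diselenide carbamates: growth inhibition notes

The source may report more compounds than this note shows. Statements on the series, on what has been measured and on what is new or still open speak of the compounds shown alone.

Measured so far in a functional assay on CCRF-CEM cells (Homo sapiens) for cytotoxicity, read by MTT assay, with a stated time of 72 h; a lower number here means a stronger inhibitor of growth, a higher number a weaker inhibitor of growth:
- compound 1 `Cc1ccc(OC(=O)Nc2ccc([Se][Se]c3ccc(NC(=O)Oc4ccc(C)cc4)cc3)cc2)cc1` gives 48500 nM
- compound 2 `C=CCOC(=O)Nc1ccc([Se]C#N)cc1` gives 38100 nM
- compound 3 `CCCCOC(=O)Nc1ccc([Se][Se]c2ccc(NC(=O)OCCCC)cc2)cc1` gives 44500 nM

Compound 2 carries the lowest of the three numbers, yet its gaps to compound 3 and to compound 1 both fall within the usual scatter, so no ordering among the three is claimed. Among the compounds with values here, no pair among them differs in a single place, so no single-change step is known.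

Compound 4 `N#C[Se]c1ccc(NC(=O)Oc2ccccc2)cc1` is not yet measured. Against compound 2 the change is phenyl in place of allyl on an oxygen next to a carbonyl group. The measured compounds, with allyl, butyl or methylphenyl at that oxygen and either selenocyanate or diselenide, all sit close together, so the step from compound 2 to compound 4 is expected to be a 1.0-fold higher number from compound 2 to compound 4 (0.02 log units; within the scatter), none beyond the scatter. Compound 4 is therefore estimated at 40000 nM in this assay, within 20000 nM to 80000 nM.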

Compound 4, concentration for total growth inhibition: 48000 nM
Compound 4: the middle estimate sits 1.2-fold (0.08 log units) below what was measured; low and high end bracket the measured number.
By their numbers in this assay, from the lowest: compounds 2, 3, 4 and 1 (each within the scatter of the next).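

In this assay, within the data shown here, the only single-place step so far, phenyl in place of allyl on an oxygen next to a carbonyl group, gives a 1.3-fold higher number from compound 2 to compound 4 (0.10 log units; within the scatter). With the selenocyanate held constant, this position therefore accepts a six-membered aromatic ring in place of allyl with no change beyond the scatter. No available evidence accounts for this result.

From the compounds shown here alone, whether an amine, a carboxylic acid or a longer chain in place of phenyl would move the number beyond the scatter remains open. Going by these compounds, the effect of selenocyanate versus diselenide with the same carbamate group also remains open.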